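Cyclopropylmethyl in Place of Neopentyl on the Ring Nitrogen

The compounds below may be only part of what the source reports. "The series", "measured", "known", "first", "only" and "open" are said of these compounds alone.

The three measured compounds share one core and differ only in the group on the saturated chain carbon bound to an aromatic nitrogen. Compound 1 `CC(C)c1onc(-c2c(Cl)cccc2Cl)c1COc1ccc(-c2nc3cc(C(=O)O)ccc3n2C)cc1` gives 25.8 nM in an assay on Huh-7 cells for agonist activity at Bile acid receptor (Homo sapiens), read by a luciferase reporter; a higher number here means that more compound is needed for the effect, a lower number that less compound is needed. Compound 2 `CCn1c(-c2ccc(OCc3c(-c4c(Cl)cccc4Cl)noc3C(C)C)cc2)nc2ccc(C(=O)O)cc21` gives 2.31 nM in this assay. Compound 3 `CC(C)c1onc(-c2c(Cl)cccc2Cl)c1COc1ccc(-c2nc3ccc(C(=O)O)cc3n2CC(C)(C)C)cc1` gives 13 nM in this assay, the second highest of the three numbers; its gap to compound 1 lies within the scatter, while the step of a 5.6-fold higher number from compound 2 to compound 3 (0.75 log units; beyond the scatter) was a modest one beyond the scatter.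

Compound 4 `CC(C)c1onc(-c2c(Cl)cccc2Cl)c1COc1ccc(-c2nc3ccc(C(=O)O)cc3n2CC2CC2)cc1` has not yet been measured in this assay. It differs from compound 3 in one place: cyclopropyl in place of tert-butyl on a saturated chain carbon bound to an aromatic nitrogen. The only step that bears on this change is the one from compound 2 to compound 3, where the group on that carbon grew and the number rose by the amount given above. Cyclopropyl sits between methyl and tert-butyl in the count of heavy atoms, so a partial return toward the number of compound 2 is expected, though the data give no step of this exact kind. Compound 4 is therefore estimated at 6 nM in this assay, with a range of 2.5 nM to 15 nM. The expected step is a 2.2-fold lower number from compound 3 to compound 4 (0.34 log units; beyond the scatter), small and close to the edge of the scatter.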

Compound 4, half-maximal effective concentration: 19.4 nM
Compound 4: middle estimate off by 3.2-fold (0.51 log units), on the low side; the measured number lies above the stated range.
By their numbers in this assay, from the lowest: compound 2; then compounds 3, 4 and 1 (each within the scatter of the next).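

In this assay, the change on a saturated chain carbon bound to an aromatic nitrogen gives a 1.5-fold higher number from compound 3 to compound 4 (0.17 log units; within the scatter) and so leaves the two compounds indistinguishable, although cyclopropyl brings a three-membered ring and 3 heavy atoms where tert-butyl has 4 heavy atoms. Methyl on that carbon, the group of compound 2, stays apart from both larger groups: the new comparison gives an 8.4-fold higher number from compound 2 to compound 4 (0.92 log units; beyond the scatter) and joins the earlier 5.6-fold higher number from compound 2 to compound 3 (0.75 log units; beyond the scatter) in showing that, among these three compounds, only compound 2 gives the low number. No measurement shown here explains why the two larger groups read alike in this assay or why methyl differs from them.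

From the compounds shown here alone, all three groups on this carbon consist of carbon and hydrogen alone, so the effect of a hydroxyl, an amine or a carboxylic acid at this place remains open. Also open, going by these compounds, is whether a longer chain such as n-propyl or a larger ring such as cyclobutyl would stay with compound 3 and compound 4 or come closer to compound 2.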